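Swapping a Pentyl Chain for Ethoxy on the Acylguanidine Core

This account rests on a few compounds, and the source may have more. Where it says the series, first, only, none or still open, it means among the compounds named here.

Measured compounds:
compound 1 `Cc1c(C(=O)N=C(N)N)cc(S(C)(=O)=O)c(Cl)c1C` — 58 nM
compound 2 `Cc1c(C(=O)N=C(N)N)cc(S(C)(=O)=O)c(Cl)c1[N+](=O)[O-]` — 44 nM
compound 3 `CCCCCc1cc(C)c(C(=O)N=C(N)N)cc1S(C)(=O)=O` — 27 nM

In a functional assay for inhibition of sodium/hydrogen exchanger (Oryctolagus cuniculus) (on this read-out lower numbers stand for stronger inhibition and higher numbers for weaker inhibition), compound 3 gives 27 nM. Against compound 1 the gap is beyond the scatter; against compound 2 it is within it, so compound 3 and compound 2 cannot be ranked against each other.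

Compound 4 `CCOc1cc(C)c(C(=O)N=C(N)N)cc1S(C)(=O)=O` is the next compound to be measured. It differs from compound 3 by ethoxy in place of pentyl on an aromatic carbon.

Among the measured compounds shown here, only one measured step joins compounds that differ in one place: a 1.3-fold lower number from compound 1 to compound 2 (0.12 log units; within the scatter). That step concerns a different position on the shared core and a different pair of groups, so it does not bear directly on the change from compound 3 to compound 4. For the measured compounds named here, no measured pair shows how an ethoxy and a pentyl group compare at this position. With nothing pointing either way, the step is expected to stay within the scatter: a 1.5-fold higher number from compound 3 to compound 4 (0.17 log units; within the scatter). The estimate for compound 4 in this assay is 40 nM, within a range from 15 nM to 110 nM.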

Compound 4, half-maximal inhibitory concentration: 19 nM
For compound 4 the middle estimate is 2.1-fold (0.32 log units) above the measured one; the measured number falls inside the stated range.
By their numbers in this assay, from the lowest: compounds 4, 3, 2 and 1 (each within the scatter of the next, the first and the last beyond it).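

In this assay the swap of ethoxy in place of pentyl gives a 1.4-fold lower number from compound 3 to compound 4 (0.15 log units; within the scatter) and so the two groups cannot be ranked at this position. Among the compounds shown here, this is the only measured pair at the aromatic carbon ortho to a methylsulfonyl group, and it shows that pentyl, with 5 heavy atoms and 0 hydrogen-bond acceptors, and ethoxy, with 3 heavy atoms and 1 hydrogen-bond acceptor, give numbers within the scatter of each other. No available evidence bears on this result.

The compounds shown leave open whether an amine, a carboxylic acid or a chain longer than pentyl at this position would also stay within the scatter of these two. They also leave open whether methoxy would read like ethoxy here.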